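Nitro for hydrogen on the pendant phenyl of compound 1

The source may report more compounds than this note shows. Statements on the series, on what has been measured and on what is new or still open speak of the compounds shown alone.

Measured compounds:
compound 1, `O=C1C(O)=C(C(c2ccccc2)c2c(-c3ccccc3)[nH]c3ccccc23)C(=O)c2ccccc21`: 26400 nM
compound 2, `COc1ccc(C(C2=C(O)C(=O)c3ccccc3C2=O)c2c[nH]c3ccccc23)cc1Br`: 25200 nM

Going by the values given here, in a toxicity assay (Homo sapiens) for cytotoxicity, read by MTT assay, with a stated time of 48 h (on this read-out lower numbers stand for stronger inhibition and higher numbers for weaker inhibition), compound 1 gives 26400 nM, the higher of the two numbers measured so far. In this assay compound 2 gives 25200 nM; the two values lie within the scatter of each other, so no order between compound 1 and compound 2 can be read from them. Compound 3, `O=C1C(O)=C(C(c2ccc([N+](=O)[O-])cc2)c2c(-c3ccccc3)[nH]c3ccccc23)C(=O)c2ccccc21`, is not yet measured. It differs from compound 1 by nitro in place of hydrogen on an aromatic carbon, para to a large group. Among the compounds with values here, no step between two measured compounds of this kind is available, so no size can be taken from the series. The expectation is no step beyond the scatter, with the number drifting either way. Compound 3 is therefore expected to give 22000 nM, in the range 8000 nM to 55000 nM. The estimated step of a 1.2-fold lower number from compound 1 to compound 3 (0.08 log units; within the scatter) is expected to stay within the scatter.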

Compound 3, half-maximal inhibitory concentration: 14200 nM
Compound 3: the middle estimate sits 1.5-fold (0.19 log units) above what was measured; the range from low to high includes it.
By their numbers in this assay, from the lowest: compounds 3, 2 and 1 (each within the scatter of the next).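

In this assay, going by these compounds alone, the change from phenyl to 4-nitrophenyl gives the first step that can be read at this position (a 1.9-fold lower number from compound 1 to compound 3 (0.27 log units; within the scatter)). The earlier compounds shown here offered no step of any kind; this one shows that nitro, with its 3 heavy atoms, can replace hydrogen on this aromatic carbon, para to a large group, without a shift beyond the scatter, so the position tolerates this change in this read-out. Nothing available bears on why the number falls where it does.

A single substituent at one place cannot show whether the position is insensitive in general, and an amine or a carboxylic acid on the same carbon would test that more widely. From the compounds shown here alone, whether nitro behaves alike on another carbon of this ring also stays open.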